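Hydroxy in Place of Hydrogen on the Shared Core

The source may hold more compounds than are shown below. What is called first, only, known or untested is meant among the compounds shown, and "the series" means these compounds.

Three compounds were measured in a functional assay on A549 cells (Homo sapiens) for inhibition, read by sulforhodamine B assay, with a stated time of 48 h; a higher number here means a weaker inhibitor of growth, a lower number a stronger inhibitor of growth:
Compound 1, `COC1=C[C@H](O)[C@H](C/C=C(\C)CC/C=C(\C)CCC=C(C)C)[C@@H](C)C1=O`: 16400 nM
Compound 2, `COC1=C(OC)[C@H](O)[C@H](C/C=C(\C)CC/C=C(\C)C[C@H](O)/C=C(\C)CO)[C@@H](C)C1=O`: 12000 nM
Compound 3, `COC1=C[C@H](O)[C@H](C/C=C(\C)CC/C=C(\C)C[C@H](O)/C=C(\C)CO)[C@@H](C)C1=O`: > 30000 nM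

Compound 3 gives only a limit of the assay, not a number. Compound 4, `COC1=C(O)[C@H](O)[C@H](C/C=C(\C)CC/C=C(\C)C[C@H](O)/C=C(\C)CO)[C@@H](C)C1=O`, differs from compound 3 by one change, (hydroxy in place of hydrogen on a double-bonded ring carbon). Among the compounds with values here, two measured steps bear on it. The chain change is an at least 1.8-fold higher number from compound 1 to compound 3 (0.26 log units; that floor lies within the scatter), which stays within the scatter. The closer comparison is at this same ring carbon: an at least 2.5-fold higher number from compound 2 to compound 3 (0.39 log units; beyond the scatter). The value of compound 3 is the limit of > 30000 nM in this assay, at which 1 of the 3 values shown sits, so the full size of that step is not known. A hydroxy at this carbon is expected to move the number back toward that of compound 2. Compound 4 is therefore estimated at 20000 nM, within 8000 nM to 60000 nM. The expected step is an at least 1.5-fold lower number from compound 3 to compound 4 (0.17 log units; that floor lies within the scatter).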

Compound 4, concentration for 50% growth inhibition: > 30000 nM
Compound 4 ended at the assay's limit (the forecaster's own chance of this, stated with the estimate: 40%); at least 1.5-fold (0.17 log units) between middle value and limit.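

On the shared core with this hydroxylated chain, a free hydroxy at this double-bonded ring carbon does not recover what methoxy gives: the change of methyl to hydrogen on that oxygen alone yields an at least 2.5-fold higher number from compound 2 to compound 4 (0.39 log units; beyond the scatter). Among these compounds, an oxygen at this carbon is therefore not enough, and only methoxy gives a measured number. The step between compound 3 and compound 4 cannot be read, as both are limits: the limit of > 30000 nM in this assay, at which 2 of the 4 values shown sit.

From the compounds shown here alone, how far compound 3 and compound 4 lie beyond that limit remains open. So does whether an ethoxy group or an amine at this carbon would give a measured number.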